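The compounds below may be only part of what the source reports. "The series", "measured", "known", "first", "only" and "open" are said of these compounds alone.

Measured compounds:
compound 1 `Cc1cc(Nc2nc(NCc3ccccc3Cl)nc3[nH]ncc23)n[nH]1` gives 668 nM in an assay on isolated protein for inhibition of serine/threonine-protein kinase PAK 4 (Homo sapiens), read by HTRF, with a stated time of 60 min; a lower number here means a stronger inhibitor, a higher number a weaker inhibitor
compound 2 `Cc1cc(Nc2nc(NCc3ccc(F)cc3)nc3[nH]ncc23)n[nH]1` gives 395 nM in this assay

Among the compounds with values here, compound 2 holds the lower of the two numbers, but the only measured step, a 1.7-fold lower number from compound 1 to compound 2 (0.23 log units; within the scatter), stays within the scatter, so the two measured compounds do not separate. Compound 3 `Cc1cc(Nc2nc(NCc3ccc(Br)cc3)nc3[nH]ncc23)n[nH]1` differs from compound 2 by bromo in place of fluoro on an aromatic carbon. Within the data shown here, no measured step exchanges one halogen for another at the same position; the single step available changes both the halogen and its place on the ring and remains within the scatter. With nothing else bearing on it, no shift beyond the scatter is expected for compound 3 in this assay, and the step is estimated as a 1.1-fold lower number from compound 2 to compound 3 (0.05 log units; within the scatter). Compound 3 is accordingly expected to give about 350 nM, with a range from 120 nM to 1000 nM.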

Compound 3, half-maximal inhibitory concentration: 1320 nM
For compound 3 the middle estimate is 3.8-fold (0.58 log units) below the measured one; measured number outside the range, above it.
By their numbers in this assay, from the lowest: compounds 2, 1 and 3 (each within the scatter of the next, the first and the last beyond it).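

In this assay, within the data shown here, the halogen at this place, on an aromatic carbon para to a large group, cannot be exchanged freely: bromo in place of fluoro gives a 3.3-fold higher number from compound 2 to compound 3 (0.52 log units; beyond the scatter) and is the first step to pass beyond the scatter. The other new step, a 2.0-fold higher number from compound 1 to compound 3 (0.30 log units; within the scatter) with 4-bromophenyl in place of 2-chlorophenyl, stays within the scatter, so compound 3 does not separate from compound 1. No supporting measurement bears on the reason for the step from fluoro to bromo.

Open, from the compounds shown here alone, is how 4-chlorophenyl, 4-methoxyphenyl or unsubstituted phenyl would read at the same place, and so whether the step belongs to bromo alone. Also open, going by these compounds, is whether a longer chain carrying the 4-fluorophenyl would hold the number seen for compound 2.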